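Dihydrofuran amides: methoxy removal and cytotoxicity

The source may report more compounds than this note shows. Statements on the series, on what has been measured and on what is new or still open speak of the compounds shown alone.

Compound 1 `C=CC1=C(C(=O)Nc2ccccc2)C(c2ccc(Cl)c(Cl)c2)OC1` and compound 2 `C=CC1=C(C(=O)Nc2ccccc2OC)C(c2ccc(Cl)c(Cl)c2)OC1` share one core and differ in a single place, (hydrogen in place of methoxy on an aromatic carbon). In a functional assay on SW480 cells (Homo sapiens) for cytotoxicity, read by MTT assay, with a stated time of 24 h (a higher number here means a weaker inhibitor, a lower number a stronger inhibitor), compound 1 gives > 100000 nM, which is a limit of the assay and not a number. Compound 2 gives > 100000 nM, again a limit. The step that the two limits leave unreadable from compound 2 to compound 1 is therefore of unreadable size; the limit of > 100000 nM in this assay, at which 3 of the 3 values shown sit, is where all three values sit. Compound 3 `C=CC1=C(C(=O)NCCC)C(c2ccc(OC)c(OC)c2)OC1` has a different core; the difference between the two cores is not broken down here. Compound 3 gives > 100000 nM, also a limit. Compound 4 `C=CC1=C(C(=O)NCCC)C(c2ccc(OC)cc2)OC1` is not yet measured and differs from compound 3 by hydrogen in place of methoxy on an aromatic carbon, the same kind of change as from compound 2 to compound 1, but here ortho to a methoxy group and meta to a large group rather than ortho to a large group. Because compound 3 gives > 100000 nM, a step that the limit leaves unreadable from compound 3 to compound 4 is expected. Compound 4 is expected at 150000 nM, between 50000 nM and 500000 nM, most likely reported again as a limit.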

Compound 4, half-maximal inhibitory concentration: > 100000 nM
Compound 4: no number, only a limit; the forecaster's own chance of this, stated with the estimate: 85%; the middle value is on the limit's open side.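

No step can be read from compound 3 to compound 4, as both values are limits and not numbers: the limit of > 100000 nM in this assay, at which 4 of the 4 values shown sit.

The compounds shown leave open whether hydrogen in place of methoxy changes activity at all in this assay.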